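A few compounds are considered here, and "the series" means these few. Any claim that something is new, unique, unknown or untested is made for them only; others in the source may bear on it.

Compound 1 `CCC(=O)N(c1ccc(Cl)cc1)C1CCCC1N(C)C` gives 0.2 mg/kg 
Compound 2 `CCC(=O)N(c1ccc(Cl)c(C)c1)C1CCCC1N(C)C` gives 2 mg/kg 
Compound 3 `CCC(=O)N(c1cccc(C(F)(F)F)c1)C1CCCC1N(C)C` gives 0.2 mg/kg 
Compound 4 `CCC(=O)N(c1ccc(C(C)=O)cc1)C1CCCC1N(C)C` has not yet been measured

In a functional assay on the whole organism for antagonist activity, with Mus musculus as the target (on this read-out higher numbers stand for an effect only at larger amounts of compound and lower numbers for an effect already at smaller amounts), compound 1 gives 0.2 mg/kg and sits level with compound 3 at the digits reported. Together they hold the lowest number of the three, and compound 2 stands furthest from compound 1.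

The change to compound 4 is acetyl in place of chloro on an aromatic carbon, para to a large group, and the count is acetyl in place of chloro on an aromatic carbon in full. The core of compound 1 stays the same.

Among the compounds with values here, only one measured step starts from compound 1, and it bears on this change only loosely. The step of a 10-fold higher number from compound 1 to compound 2 (1.00 log units; beyond the scatter) came with methyl in place of hydrogen on an aromatic carbon, so a small addition to this ring can matter. Against that, compound 3 carries trifluoromethyl and no chloro yet gives 0.2 mg/kg in the same assay, so losing chloro need not cost much. Within the data shown here, no measured compound carries acetyl.

A modest move toward a higher number is therefore expected in this assay, smaller than the step to compound 2. The estimated change is a 2.5-fold higher number from compound 1 to compound 4 (0.40 log units; beyond the scatter) and it remains uncertain. The expected value for compound 4 is 0.5 mg/kg with an estimated range from 0.1 mg/kg to 2.5 mg/kg on this thin evidence.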

Compound 4, dose for half-maximal effect: 40 mg/kg
The estimate for compound 4 lay 80-fold (1.90 log units) below the measured number; the measured number lies above the stated range.
By their numbers in this assay, from the lowest: compounds 1 and 3 (each within the scatter of the next); then compound 2; then compound 4.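

In this assay, acetyl in place of chloro on an aromatic carbon, para to a large group, brought a 200-fold higher number from compound 1 to compound 4 (2.30 log units; beyond the scatter). This large step exceeds a 10-fold higher number from compound 1 to compound 2 (1.00 log units; beyond the scatter), which came with methyl in place of hydrogen on an aromatic carbon while chloro stayed in place, so only the newer pair shows what happens when the chloro itself is exchanged at this position, and it shows that this exchange can shift the dose very strongly. Nothing among the data shown accounts for the size of this step.

The compounds shown leave open whether other groups at this place, such as a methoxy group, a nitrile or an amine, would stay close to compound 1 or move as far as compound 4, and whether the size of the step belongs to the carbonyl or to the acetyl group as a whole, which a simple ethyl group at the same carbon could help to separate. A single pair also cannot tell whether the same exchange would give a step of this size on a ring that carries a second substituent, as compound 2 does.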